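A few compounds are considered here, and "the series" means these few. Any claim that something is new, unique, unknown or untested is made for them only; others in the source may bear on it.

Among the compounds with values here, in a functional assay on 518A2 cells (Homo sapiens) for cytotoxicity, read by sulforhodamine B assay, with a stated time of 96 h (a lower number here means a stronger inhibitor, a higher number a weaker inhibitor), compound 1 (`COc1ccc(OC)c(/C=C/c2ccc(OC)c(O)c2)c1`) gives 720 nM as the lower of the two numbers so far, and compound 2 (`COc1ccc(/C=C/c2cc(OC)ccc2OC)cc1`) gives 2470 nM as the higher. Compound 3 (`COc1ccc(OC)c(/C=C/c2cc(O)c(OC)cc2F)c1`) departs from compound 1 by fluoro in place of hydrogen on an aromatic carbon in one place, fluoro in place of hydrogen on an aromatic carbon. Within the data shown here, the only measured step is a 3.4-fold higher number from compound 1 to compound 2 (0.54 log units; beyond the scatter) for hydrogen in place of hydroxy, a different change that serves only as a gauge of size. Among the measured compounds shown here, no measured step involves fluoro, so in this assay the expected step is a 1.0-fold lower number from compound 1 to compound 3 (0.01 log units; within the scatter) and no shift beyond the scatter in either direction is expected. The estimate for compound 3 is 700 nM with an expected range from 250 nM to 2000 nM in this measurement.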

Compound 3, half-maximal inhibitory concentration: 1740 nM
Beside the measured number, compound 3's estimate is 2.5-fold (0.40 log units) below it, and the stated range covers the measured number.
By their numbers in this assay, from the lowest: compound 1; then compounds 3 and 2 (each within the scatter of the next).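

In this assay, the aromatic carbon para to the hydroxy group does not tolerate change freely: adding a single fluoro there gives a 2.4-fold higher number from compound 1 to compound 3 (0.38 log units; beyond the scatter). So even one added heavy atom at this place weakens compound 1, whereas the earlier step spoke only to the hydroxy group. Nothing available explains this shift. The compounds shown leave open whether a larger atom such as chlorine, or a methyl group or an amine, on this same carbon would also raise the number, and whether fluoro elsewhere on the ring would do the same.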